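Bromo added to the cyanophenyl arm of compound 2

The compounds below may be only part of what the source reports. "The series", "measured", "known", "first", "only" and "open" are said of these compounds alone.

Compound 2 `Cn1c(=O)cnn(CCCCN2CCN(c3ccccc3C#N)CC2)c1=O` gives the lowest of the two numbers in an assay for displacement of a labelled ligand from Adrenergic receptor alpha-1 (Homo sapiens) (on this read-out lower numbers stand for stronger inhibition and higher numbers for weaker inhibition), at 7.3 nM; compound 1 `CN(C)c1ccccc1N1CCN(CCCCn2ncc(=O)n(C)c2=O)CC1` gives 350 nM, and the step of a 48-fold lower number from compound 1 to compound 2 (1.68 log units; beyond the scatter) separates them. Compound 3 `Cn1c(=O)cnn(CCCCN2CCN(c3c(Br)cccc3C#N)CC2)c1=O` differs from compound 2 by bromo in place of hydrogen on an aromatic carbon. Among the measured compounds shown here, no measured step bears on this change: the single step seen, from compound 1 to compound 2, exchanges one group for another rather than adding a second group to the ring. For compound 3 the number is therefore expected to remain near that of compound 2. The step expected, a 1.1-fold higher number from compound 2 to compound 3 (0.04 log units; within the scatter), stays within the usual scatter. Compound 3 is estimated at 8 nM, in the range 3 nM to 25 nM.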

Compound 3, inhibition constant: 450 nM
For compound 3 the middle estimate is 56-fold (1.75 log units) below the measured one, outside the stated range (above it).
By their numbers in this assay, from the lowest: compound 2; then compounds 1 and 3 (each within the scatter of the next).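

In this assay, bromo in place of hydrogen on the aromatic carbon ortho to a large group and meta to a cyano group is far from a silent addition (a 62-fold higher number from compound 2 to compound 3 (1.79 log units; beyond the scatter)). The 2-bromo-6-cyanophenyl arm gives up the whole advantage that 2-cyanophenyl held over 2-(dimethylamino)phenyl (a 1.3-fold higher number from compound 1 to compound 3 (0.11 log units; within the scatter)). No measurement at hand explains this step. From the compounds shown here alone, whether the drop is specific to bromo stays open: fluoro or methyl on the same carbon would test that. Bromo elsewhere on the ring would show whether this carbon alone is so sensitive.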